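Extending the amide side chain of compound 1 with a secondary amine

A few compounds are considered here, and "the series" means these few. Any claim that something is new, unique, unknown or untested is made for them only; others in the source may bear on it.

Among the measured compounds shown here, compound 1, `CCC(=O)Nc1ccc(C2=NNC(=O)CC2)cc1`, is the stronger of the two compounds measured so far. In a functional assay for inhibition, with Homo sapiens as the target (a lower number here means that less compound is needed, a higher number that more compound is needed for the effect), compound 1 gives 0.64 ug/mL. For the measured compounds named here, the only other measured compound, compound 2, `CC1CC(c2ccc(N)cc2)=NNC1=O`, differs from it in more than one place, so no single step can be traced between them; in this assay compound 2 gives 43.8 ug/mL, and the gap between the two values lies far beyond the scatter.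

Compound 3, `CCC(C)NCC(=O)Nc1ccc(C2=NNC(=O)CC2)cc1`, has not yet been measured. It differs from compound 1 as follows: (sec-butyl)amino in place of methyl on a saturated chain carbon bound to a carbonyl carbon. The amide, the shared core and the aryl ring remain unchanged; only the end of the acyl chain carries the new group.

Going by the values given here, with no single-site step between measured compounds to draw on, the expected size of the step in this assay is uncertain. The author expects compound 3 to stay near compound 1, with the change from compound 1 to compound 3 estimated at a 2.3-fold higher number from compound 1 to compound 3 (0.37 log units; beyond the scatter), leaning slightly toward a higher number. The estimate for compound 3 is 1.5 ug/mL, within a range of 0.3 ug/mL to 8 ug/mL.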

Compound 3, half-maximal effective concentration: about 21.5 ug/mL
Beside the measured number, compound 3's estimate is 14-fold (1.16 log units) below it; the whole stated range lies below it.
By their numbers in this assay, from the lowest: compound 1; then compound 3; then compound 2.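

The end of the acyl chain of compound 1 turns out not to be a free place for adding bulk: in this assay, putting (sec-butyl)amino in place of methyl on a saturated chain carbon bound to a carbonyl carbon gives a 34-fold higher number from compound 1 to compound 3 (1.53 log units; beyond the scatter) and so a large step toward needing more compound. The amide, the shared core and the aryl ring stay the same in this pair, so this single change at the chain end is enough to move the value well beyond the scatter. Nothing available here accounts for the size of this step.

With only one group tested at this place, the compounds shown cannot separate the contribution of the amine nitrogen from that of the sec-butyl group attached to it. As far as these compounds go, it remains open whether a smaller dimethylamino group, a hydroxyl group or a plain butyl chain at the same place would stay close to compound 1 or give a similarly large step.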